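The source may hold more compounds than are shown below. What is called first, only, known or untested is meant among the compounds shown, and "the series" means these compounds.

Measured so far:
compound 1 `CCCc1nc(-c2ccccc2)c(CNCCCN2CCN(c3ccccc3)CC2)o1` gives 43.7%
compound 2 `CCCc1nc(-c2ccccc2)c(CNCCN2CCN(c3ccc(C)cc3)CC2)o1` gives 48.1%
compound 3 `CCCc1nc(-c2ccccc2)c(CNCCN2CCN(c3cccc(Cl)c3)CC2)o1` gives 51.2%

All three values come from an assay on HEK293 cells for inhibition of Voltage-dependent T-type calcium channel subunit alpha-1G (Homo sapiens), read by fluorescence, tested at 10 uM; a lower number here means less inhibition, a higher number more inhibition at the concentration tested (going by the name of the read-out). The three numbers sit close together: compound 1 is not separated from compound 2 or from compound 3 by more than the usual scatter, so no order among them can be read from these data.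

Going by the values given here, the only single-point step measured is a number 3.1 percentage points higher from compound 2 to compound 3 (within the scatter), a swap of one substituent pattern for another on the phenyl carried by the piperazine nitrogen, and it stays inside the scatter.

Compound 4 `CCCc1nc(-c2ccccc2)c(CNCCCN2CCN(c3ccc(OC)cc3)CC2)o1` is the next compound of the series. It differs from compound 1 by methoxy in place of hydrogen on an aromatic carbon. Among the compounds with values here, no measured step covers a methoxy group at this position, and the only change on the same phenyl ring, the step from compound 2 to compound 3, did not move this assay beyond the scatter. On that basis no step beyond the scatter is expected here either.

Compound 4 is therefore estimated at 47%, with a range from 32% to 62%. This expectation corresponds to a step of a number 3.3 percentage points higher from compound 1 to compound 4 (within the scatter), which is expected to remain within the scatter.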

Compound 4, a percentage reported as inhibition, at one concentration (the size of the read-out at that concentration, not a potency): 42.1%
The estimate for compound 4 lay 4.9 percentage points above the measured number; the measured number falls inside the stated range.
By their numbers in this assay, from the lowest: compounds 4, 1, 2 and 3 (each within the scatter of the next).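

In this assay the change from phenyl to 4-methoxyphenyl, on an aromatic carbon para to a large group, is a number 1.6 percentage points lower from compound 1 to compound 4 (within the scatter). Going by these compounds alone, it is the first single-place step measured from the unsubstituted phenyl, and adding methoxy at this position leaves the read-out within the scatter, so the numbers of the two compounds in this assay are level. Nothing available explains why the number stays within the scatter here.

As far as these compounds go, whether an amine, a carboxylic acid or a trifluoromethyl group at this same position would give a step beyond the scatter remains open. Also open, from the compounds shown here alone, is whether any change elsewhere on the shared core, such as a longer chain in place of the propyl group, would separate compounds in this assay.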